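The compounds below may be only part of what the source reports. "The series", "measured", "known", "first", "only" and "open" are said of these compounds alone.

All three measured compounds share one core, and the changes sit on a single amine nitrogen. In a functional assay on HEL cells (Homo sapiens) for cytotoxicity, read by microscopy (a lower number here means that less compound is tolerated, a higher number that more compound is tolerated), compound 1 `CCOC(=O)CNC(=O)NC1=CS(=O)(=O)O[C@@]12[C@@H](CO[Si](C)(C)C(C)(C)C)O[C@@H](n1cc(C)c(=O)n(C)c1=O)[C@@H]2O[Si](C)(C)C(C)(C)C` gives 16000 nM. Compound 2 `COC(=O)NC1=CS(=O)(=O)O[C@@]12[C@@H](CO[Si](C)(C)C(C)(C)C)O[C@@H](n1cc(C)c(=O)n(C)c1=O)[C@@H]2O[Si](C)(C)C(C)(C)C` gives only a limit of this assay, >= 50000 nM, not a number. Compound 3 `Cc1cn([C@@H]2O[C@H](CO[Si](C)(C)C(C)(C)C)[C@@]3(OS(=O)(=O)C=C3NCC(=O)C(=O)O)[C@H]2O[Si](C)(C)C(C)(C)C)c(=O)n(C)c1=O` gives 400000 nM, the highest of the two real numbers here, so of these compounds the most is tolerated of compound 3. The step of a 25-fold higher number from compound 1 to compound 3 (1.40 log units; beyond the scatter) is large, whereas the step that the limit leaves unreadable from compound 2 to compound 3 cannot be sized because compound 2 sits at a limit (the limit of >= 50000 nM in this assay, at which 1 of the 3 values shown sits).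

Compound 4 `Cc1cn([C@@H]2O[C@H](CO[Si](C)(C)C(C)(C)C)[C@@]3(OS(=O)(=O)C=C3NC(=O)c3ccccc3)[C@H]2O[Si](C)(C)C(C)(C)C)c(=O)n(C)c1=O` has not been measured. It differs from compound 3 in one place: benzoyl in place of (carboxycarbonyl)methyl on an amine nitrogen. Among the measured compounds shown here, the one readable step bearing on this change, read backwards from compound 3 to compound 1, showed that exchanging the (carboxycarbonyl)methyl group for a carbonyl-bearing group lowered the tolerated concentration by a large step. Since the benzoyl group also brings a carbonyl and no acid, compound 4 is expected to sit below compound 3, at roughly 30000 nM, between 8000 nM and 150000 nM, which is an expected step of a 13-fold lower number from compound 3 to compound 4 (1.12 log units; beyond the scatter).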

Compound 4, minimum cytotoxic concentration: >= 3200 nM
Compound 4: a limit, no number (the forecaster's own chance of this, stated with the estimate: 25%); the middle value does not contradict the limit.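

Compound 4 gives only a limit in this assay, >= 3200 nM, not a number. None of the steps from compound 1, compound 2 or compound 3 to compound 4 can be read. The compounds shown leave open how benzoyl on the amine nitrogen compares with (carboxycarbonyl)methyl there.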